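The source may report more compounds than this note shows. Statements on the series, on what has been measured and on what is new or still open speak of the compounds shown alone.

Measured so far in a functional assay (Homo sapiens) for inhibition; on this read-out higher numbers stand for weaker inhibition and lower numbers for stronger inhibition:
compound 1 `COc1cc(/C=C/C(=O)c2ccccc2N(C)C)cc(OC)c1` gives 5700 nM;
compound 2 `COc1cc(/C=C/C(=O)c2ccccc2O)cc(OC)c1` gives 8100 nM;
compound 3 `O=C(/C=C/c1ccc(O)cc1)c1ccc(O)cc1` gives 59000 nM.

Compound 3 stands highest of the three in this assay. How its core differs from the core of compound 2 is not broken down here. Compound 2 and compound 1 differ in one place only, (dimethylamino in place of hydroxy on an aromatic carbon), and that change gave a 1.4-fold lower number from compound 2 to compound 1 (0.15 log units; within the scatter).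

Compound 4 `CN(C)c1ccc(/C=C/C(=O)c2ccc(O)cc2)cc1` is not yet measured. It differs from compound 3 by dimethylamino in place of hydroxy on an aromatic carbon; the entering and leaving groups are the same as from compound 2 to compound 1, but the place is ortho to a large group in compound 1 and para to a large group in compound 4, so it is the same kind of change rather than the same change. Because the earlier step was a 1.4-fold lower number from compound 2 to compound 1 (0.15 log units; within the scatter), a small step is expected here too: compound 4 is estimated to give 45000 nM in this assay, between 15000 nM and 130000 nM, a step of a 1.3-fold lower number from compound 3 to compound 4 (0.12 log units; within the scatter).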

Compound 4, half-maximal inhibitory concentration: 130000 nM
Beside the measured number, compound 4's estimate is 2.9-fold (0.46 log units) below it; low and high end bracket the measured number.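

In this assay, dimethylamino in place of hydroxy on an aromatic carbon gave a 2.2-fold higher number from compound 3 to compound 4 (0.34 log units; beyond the scatter) on the core of compound 3. The change therefore does not carry over from one core to another as a fixed step, and the two steps differ by more than the scatter: the same change on two cores in this assay, a 1.4-fold lower number (0.15 log units; within the scatter) from compound 2 to compound 1 and a 2.2-fold higher number (0.34 log units; beyond the scatter) from compound 3 to compound 4, 3.1-fold (0.50 log units) apart, beyond the scatter of two such steps. For the compounds shown here, with only two pairs, and with the change sitting at a different place in each, the data cannot tell whether the core or the place accounts for this gap.

The compounds shown leave open how a primary amine or a carboxylic acid in place of hydroxy would behave on either core. They also leave open whether dimethylamino at one matching place on both cores would give matching steps.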